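The source may hold more compounds than are shown below. What is called first, only, known or untested is meant among the compounds shown, and "the series" means these compounds.

Measured in a functional assay on L1210 cells (Mus musculus) for antiproliferative activity, with a stated time of 48 h; a higher number here means a weaker inhibitor, a lower number a stronger inhibitor:
- compound 1 `C=C(Br)C(=O)Nc1ccc(C(=O)/C=C/c2cc(OC)c(OC)c(OC)c2)cc1`: 1500 nM
- compound 2 `COc1cc(/C=C/C(=O)c2ccc(N)cc2)cc(OC)c1`: 6000 nM

Of these two, compound 2 at 6000 nM has the higher number and so is the weaker inhibitor, and its gap to compound 1 lies beyond the usual scatter. Compound 3 `COc1cc(/C=C/C(=O)c2ccc(N)cc2)cc(OC)c1OC` has not yet been measured. It differs from compound 2 by methoxy in place of hydrogen on an aromatic carbon, with methoxy in place of hydrogen on an aromatic carbon. Within the data shown here, no measured pair shows this change alone, so the expectation in this assay is only a small move towards a lower number, not clearly beyond the scatter. The estimated change is a 1.7-fold lower number from compound 2 to compound 3 (0.23 log units; within the scatter). For compound 3 the estimated value is 3500 nM, with an expected range of 1000 nM to 10000 nM.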

Compound 3, half-maximal inhibitory concentration: 7800 nM
The estimate for compound 3 lay 2.2-fold (0.35 log units) below the measured number; the range from low to high includes it.
By their numbers in this assay, from the lowest: compound 1; then compounds 2 and 3 (each within the scatter of the next).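

In this assay, methoxy in place of hydrogen on the aromatic carbon ortho to two methoxy groups gives a 1.3-fold higher number from compound 2 to compound 3 (0.11 log units; within the scatter), so at this position the added group leaves the number within the scatter. By contrast, hydrogen in place of (1-bromoethenyl)carbonyl on the nitrogen gives a 5.2-fold higher number from compound 1 to compound 3 (0.72 log units; beyond the scatter), a step beyond the scatter at a different place on the molecule. No measurement here explains either step. Still open, on these data alone, is whether a hydroxyl or a longer ethoxy chain at this position would also stay within the scatter, and whether a simple acetyl on the nitrogen would match the (1-bromoethenyl)carbonyl group.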